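The source may hold more compounds than are shown below. What is called first, only, known or untested is meant among the compounds shown, and "the series" means these compounds.

Measured compounds in a functional assay on HEK293 cells for negative allosteric modulation of metabotropic glutamate receptor 5 (Homo sapiens), read by FLIPR and calcium flux; on this read-out higher numbers stand for weaker inhibition and lower numbers for stronger inhibition:
compound 1 `O=C(Nc1cccc(Cl)c1)c1noc2c1CCC2` gives 63 nM
compound 2 `Cc1cccc(NC(=O)c2nn(C)c(-c3ccc(F)cc3)c2C)n1` gives 1.1 nM
compound 3 `Cc1cccc(NC(=O)c2nn(C)c(-c3ccc(N(C)C)cc3)c2C)n1` gives 645 nM

Compound 2 stands at the lowest number of the three. Its nearest neighbour is compound 1, which sits well beyond the scatter above it, and the largest gap is to compound 3, where the step of a 590-fold higher number from compound 2 to compound 3 (2.77 log units; beyond the scatter) follows a single change on the aromatic ring that hangs from the shared core.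

Compound 4 `Cc1cccc(NC(=O)c2nn(C)c(OC3CCCCC3)c2C)n1` is not yet measured. It differs from compound 2 in one place: cyclohexyloxy in place of 4-fluorophenyl on an aromatic carbon. Among the compounds with values here, the only measured step that touches the same place is the one from compound 2 to compound 3, and that step was large. It does not cover the present change, since there the aromatic ring stayed and only its substituent moved, whereas here the whole ring gives way to a saturated ring joined through oxygen. Within the data shown here, the one precedent at this place therefore argues that changes here cost a great deal, but with a single comparison the size is uncertain.

The step of a 140-fold higher number from compound 2 to compound 4 (2.13 log units; beyond the scatter) is expected to be a clear rise in the number. For compound 4 the estimate is 150 nM, with a range from 15 nM to 1500 nM in this assay.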

Compound 4, half-maximal inhibitory concentration: 92 nM
Estimate against measurement, compound 4: 1.6-fold (0.21 log units) above; measured number inside the range.
By their numbers in this assay, from the lowest: compound 2; then compounds 1 and 4 (each within the scatter of the next); then compound 3.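

In this assay, within the data shown here, the step of an 84-fold higher number from compound 2 to compound 4 (1.92 log units; beyond the scatter) is large and gives the first reading of replacing the whole 4-fluorophenyl on this aromatic carbon, rather than only a substituent on that ring. Keeping an aromatic ring here is not needed for inhibition in the nanomolar range and does not by itself keep the number low: compound 4, with cyclohexyloxy in a non-aromatic ring, gives 92 nM, while compound 3, which retains the aromatic ring, gives 645 nM. Nothing available explains the size of the step to cyclohexyloxy, which also brings in a hydrogen-bond acceptor at the same heavy-atom count.

From the compounds shown here alone, the change in compound 4 swaps the aromatic ring for a non-aromatic one and adds the oxygen link in a single move, so the share of the step belonging to each remains open. A phenoxy group would keep the oxygen with an aromatic ring and a directly attached cyclohexyl group would keep the saturated ring without the oxygen, and either would help separate the two.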